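The source may report more compounds than this note shows. Statements on the series, on what has been measured and on what is new or still open speak of the compounds shown alone.

Compound 1 `CC(C)CCn1ccc(N2CCCCC2)c(C#N)c1=O` gives 31600 nM in a functional assay on CHO cells for positive allosteric modulation of metabotropic glutamate receptor 2 (Homo sapiens), with a stated time of 30 min; a higher number here means that more compound is needed for the effect, a lower number that less compound is needed.
Compound 2 `N#Cc1c(N2CCC(c3ccccc3)CC2)ccn(CC2CC2)c1=O` gives 151 nM in this assay.
Compound 3 `N#Cc1c(N2CCC(c3ccc(F)cc3)CC2)ccn(CC2CC2)c1=O` gives 89 nM in this assay.

Among these three, compound 3 carries the lowest number, but compound 2 lies within the scatter of it, and only compound 1 is clearly set apart from the other two. Compound 4 `COc1ccc(C2CCN(c3ccn(CC4CC4)c(=O)c3C#N)CC2)cc1` has not yet been measured in this assay. It differs from compound 3 by methoxy in place of fluoro on an aromatic carbon. Among the measured compounds shown here, no measured step replaces one group by another at that carbon; the only related step is a 1.7-fold lower number from compound 2 to compound 3 (0.23 log units; within the scatter), which put the fluoro onto a bare ring position and changed little. For the exchange of fluoro for methoxy the data give no direct guide, so a step no larger than the scatter, a 1.2-fold higher number from compound 3 to compound 4 (0.09 log units; within the scatter), is expected. Compound 4 is therefore estimated at 110 nM, with a range from 35 nM to 400 nM.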

Compound 4, half-maximal effective concentration: 98 nM
Compound 4: middle estimate off by 1.1-fold (0.05 log units), on the high side; the measured number falls inside the stated range.
By their numbers in this assay, from the lowest: compounds 3, 4 and 2 (each within the scatter of the next); then compound 1.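

In this assay, the change from 4-fluorophenyl to 4-methoxyphenyl gives a 1.1-fold higher number from compound 3 to compound 4 (0.04 log units; within the scatter) and so does not separate the two groups, while methoxy in place of hydrogen gives a 1.5-fold lower number from compound 2 to compound 4 (0.19 log units; within the scatter) as well. Among the compounds shown here, this position, para to a large group, has now carried hydrogen, fluoro and methoxy with no step leaving the scatter, even with the added heavy atom and hydrogen-bond acceptor of methoxy. No measured evidence bears on this result.

Going by these compounds, whether an amine, a carboxylic acid or a longer alkoxy chain here would also stay within the scatter remains open. Also open, on these data alone, is how fluoro and methoxy would read on another carbon of that ring.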